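The compounds below may be only part of what the source reports. "The series", "measured", "known", "first", "only" and "open" are said of these compounds alone.

Working notes on the urea-aryl series. The aryl group on the amide-type nitrogen is the only variable across the three measured compounds. Compound 1 `NS(=O)(=O)c1ccc(NC(=O)Nc2cccc(-c3nc(-c4ccc(NC(=O)c5cccnc5)cc4Cl)no3)c2)cc1` carries 4-sulfamoylphenyl there. In a functional assay on MDA-MB-231 cells (Homo sapiens) for antiproliferative activity, read by MTT assay, with a stated time of 72 h (on this read-out higher numbers stand for weaker inhibition and lower numbers for stronger inhibition), compound 1 gives only a limit, > 10000 nM. Compound 2 `COc1cccc(NC(=O)Nc2cccc(-c3nc(-c4ccc(NC(=O)c5cccnc5)cc4Cl)no3)c2)c1` carries 3-methoxyphenyl, and in this assay compound 2 gives 6700 nM. Compound 3 `C#Cc1ccc(NC(=O)Nc2cccc(-c3nc(-c4ccc(NC(=O)c5cccnc5)cc4Cl)no3)c2)cc1` carries 4-ethynylphenyl. In this assay compound 3 gives only a limit, > 10000 nM. Compound 3 therefore stands at the ceiling of the series, a position it shares with another value (the limit of > 10000 nM in this assay, at which 2 of the 3 values shown sit). The steps of an at least 1.4-fold lower number from compound 1 to compound 2 (0.17 log units; that floor lies within the scatter) and an at least 1.4-fold higher number from compound 2 to compound 3 (0.17 log units; that floor lies within the scatter) each rest on that floor, and the step that the two limits leave unreadable from compound 1 to compound 3.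

Compound 4 `CC(=O)Nc1ccc(NC(=O)Nc2cccc(-c3nc(-c4ccc(NC(=O)c5cccnc5)cc4Cl)no3)c2)cc1` differs from compound 3 by acetamido in place of ethynyl on an aromatic carbon. Within the data shown here, no measured step exchanges a group on that aromatic carbon for acetamido, so the nearest guide is the general picture: two of three values sit at the limit, and the one numbered value, compound 2, is itself weak in this assay. No change beyond the scatter is therefore expected for compound 4 in this assay, and compound 4 is expected to remain at or near the limit. The estimate for compound 4 is 12000 nM, with a range from 4000 nM to 40000 nM. The expected step is a step that the limit leaves unreadable from compound 3 to compound 4.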

Compound 4, half-maximal inhibitory concentration: > 10000 nM
Compound 4: a limit, no number; the forecaster's own chance of this, stated with the estimate: 65%; the middle value is on the limit's open side.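

Acetamido on this aromatic carbon, para to a large group, enters with a hydrogen-bond donor and a hydrogen-bond acceptor that ethynyl does not have, yet in this assay compound 4 gives > 10000 nM, which is a limit and not a number. The one readable step is an at least 1.4-fold higher number from compound 2 to compound 4 (0.17 log units; that floor lies within the scatter), and the steps that join two limits cannot be read. 4-Acetamidophenyl thus joins 4-sulfamoylphenyl and 4-ethynylphenyl at the ceiling, so this position has given no number in the compounds shown, and the only numbered compound, compound 2, carries 3-methoxyphenyl instead: the limit of > 10000 nM in this assay, at which 3 of the 4 values shown sit.

Going by these compounds, what an amine or a carboxylic acid on this same aromatic carbon would give remains open, including whether any group there can bring the read-out under the limit. Also open is whether the number of compound 2 belongs to the methoxy group itself or to where it sits, as no pair shown holds one group at two places on the ring.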